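Moving the methyl group: from compound 3 to compound 4

The compounds below may be only part of what the source reports. "The series", "measured", "known", "first", "only" and "open" are said of these compounds alone.

Measured in a functional assay on HCT-116 cells (Homo sapiens) for antiproliferative activity, with a stated time of 72 h; on this read-out lower numbers stand for stronger inhibition and higher numbers for weaker inhibition:
compound 1 `O=C(COc1ccc(CN2CC=C(c3c[nH]c4cccc(F)c34)CC2)c(F)c1)NO`: 1220 nM
compound 2 `O=C(COc1ccc(C(=O)NC2CC=C(c3c[nH]c4cccc(F)c34)CC2)cc1)NO`: > 5000 nM (a limit, not a number)
compound 3 `Cc1ccc2[nH]cc(C3=CCC(NCc4ccc(OCC(=O)NO)cc4F)CC3)c2c1`: 445 nM

In this assay compound 3 gives 445 nM, the lower of the two actual numbers. Compound 1 gives 1220 nM, a higher number, and this gap lies beyond the scatter. Compound 2 gives > 5000 nM, which is a limit of the assay.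

The next compound to be tested is compound 4 `Cc1[nH]c2ccccc2c1C1=CCC(NCc2ccc(OCC(=O)NO)cc2F)CC1`, which has the same atoms as compound 3, joined differently: 2-methyl-1H-indol-3-yl in place of 5-methyl-1H-indol-3-yl on a double-bonded ring carbon. It carries 2-methyl-1H-indol-3-yl in place of 5-methyl-1H-indol-3-yl on a double-bonded ring carbon.

Among the measured compounds shown here, no two measured compounds differ in only one place, so the data give no direct measure of such a change. The expectation therefore starts from compound 3 at 445 nM, and no change beyond the scatter is expected, with a slight lean towards weaker inhibition. The expected step is a 1.2-fold higher number from compound 3 to compound 4 (0.09 log units; within the scatter). For compound 4 the estimated value is 550 nM, with an expected range of 200 nM to 1500 nM.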

Compound 4, half-maximal inhibitory concentration: 99 nM
Estimate against measurement, compound 4: 5.6-fold (0.74 log units) above, and the stated range ends above it.
By their numbers in this assay, from the lowest: compound 4; then compound 3; then compound 1. At a limit, above all of these: compound 2.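

Replacing 5-methyl-1H-indol-3-yl with 2-methyl-1H-indol-3-yl gives a 4.5-fold lower number from compound 3 to compound 4 (0.65 log units; beyond the scatter) in this assay. Among the compounds shown here, this is the first pair that differs in only one place, and it shows that, with the atoms unchanged, where the methyl group sits on this group on a double-bonded ring carbon makes a difference beyond the scatter. Nothing in the data shown accounts for this step.

As far as these compounds go, it remains open whether the methyl group itself matters or only its location, since the comparison does not extend to the plain 1H-indol-3-yl group or to 2-ethyl-1H-indol-3-yl and 2-chloro-1H-indol-3-yl. From the compounds shown here alone, it is also open whether the same exchange would lower the number to a similar extent on the core of compound 1.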